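Compound 3: trifluoromethyl in place of fluoro

A few compounds are considered here, and "the series" means these few. Any claim that something is new, unique, unknown or untested is made for them only; others in the source may bear on it.

Measured in an ADME assay on HepG2 cells (Homo sapiens) for cytotoxicity, with a stated time of 72 h; on this read-out higher numbers stand for an effect only at larger amounts of compound and lower numbers for an effect already at smaller amounts:
Compound 1 `Cc1ccc(NC(=O)Nc2cc(C)nc3ccccc23)cc1`: > 25000 nM, a limit
Compound 2 `Cc1cc(NC(=O)Nc2ccc(F)cc2)c2ccccc2n1`: > 25000 nM, a limit

In this assay compound 2 gives > 25000 nM, which is a limit of the assay and not a number. The measured compounds stand together: the limit of > 25000 nM in this assay, at which 2 of the 2 values shown sit.

Compound 3 `Cc1cc(NC(=O)Nc2ccc(C(F)(F)F)cc2)c2ccccc2n1` differs from compound 2 in one place, with trifluoromethyl in place of fluoro on an aromatic carbon, para to a large group (trifluoromethyl in place of fluoro on an aromatic carbon). Within the data shown here, the one measured step that bears on this change is a step that the two limits leave unreadable from compound 1 to compound 2. It gives no size to carry over, so no step beyond the scatter is expected in this assay, and no direction can be named. The expected step is a number no higher from compound 2 to compound 3 (the limit leaves the size open). For compound 3 the estimate is 25000 nM, expected to fall between 12000 nM and 40000 nM.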

Compound 3, half-maximal effective concentration: 23000 nM
Estimate against measurement, compound 3: 1.1-fold (0.04 log units) above; the measured number falls inside the stated range.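

In this assay, among these compounds, compound 3 gives 23000 nM, the first reading that is a number and not a limit of the assay. At this aromatic carbon, para to a large group, trifluoromethyl gives an at least 1.0-fold lower number from compound 2 to compound 3 (0.03 log units; that floor lies within the scatter), and in place of methyl it gives an at least 1.0-fold lower number from compound 1 to compound 3 (0.03 log units; that floor lies within the scatter); neither floor shows a change beyond the scatter. The other two values remain limits and not numbers: the limit of > 25000 nM in this assay, at which 2 of the 3 values shown sit.

Going by these compounds, how far compound 1 and compound 2 lie past that limit stays open, so the true size of both steps is unknown, and the step between those two compounds cannot be read. Also open, on these data alone, is what an amine or a carboxylic acid on this carbon would give in this assay.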